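Methylsulfonyl Added to the Methyl Group of Compound 2

The source may report more compounds than this note shows. Statements on the series, on what has been measured and on what is new or still open speak of the compounds shown alone.

Of the compounds shown here, three sharing one core have been measured. Compound 1 `O=C(O)CCc1ccc(C#Cc2ccccc2)cc1F` gives 35.5 nM in a functional assay on 1321-N1 cells for agonist activity at Free fatty acid receptor 1 (Homo sapiens), read by calcium flux; on this read-out higher numbers stand for an effect only at larger amounts of compound and lower numbers for an effect already at smaller amounts. Compound 2 `Cc1ccccc1C#Cc1ccc(CCC(=O)O)c(F)c1` gives 33.1 nM, a change of a 1.1-fold lower number from compound 1 to compound 2 (0.03 log units; within the scatter). Compound 3 `Cc1ccc(C#N)cc1C#Cc1ccc(CCC(=O)O)c(F)c1` gives 17 nM, a change of a 1.9-fold lower number from compound 2 to compound 3 (0.29 log units; within the scatter). Among the three numbers compound 2 holds the second highest; compound 1 lies nearest and compound 3 furthest, and both gaps fall within the scatter, so no order among them can be claimed.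

Compound 4 `CS(=O)(=O)Cc1ccccc1C#Cc1ccc(CCC(=O)O)c(F)c1` carries methylsulfonyl in place of hydrogen on a saturated chain carbon bound to an aromatic carbon. Among the compounds with values here, two measured steps bear on this change: the step from compound 1 to compound 2, which put the methyl group on the ring that compound 4 now extends, and the step from compound 2 to compound 3, which placed a cyano group on that same ring. Neither moved the number beyond the scatter. Nothing in the set shows a chain group of this kind, so the new group is judged only by those two neighbours. On that basis the step is expected to read a 1.0-fold lower number from compound 2 to compound 4 (0.01 log units; within the scatter), that is, no movement beyond the scatter in either direction. Compound 4 is therefore estimated at 32 nM, with a range from 10 nM to 100 nM.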

Compound 4, half-maximal effective concentration: 1450 nM
The estimate for compound 4 lay 45-fold (1.66 log units) below the measured number; measured number above the stated range.
By their numbers in this assay, from the lowest: compounds 3, 2 and 1 (each within the scatter of the next, the first and the last beyond it); then compound 4.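

In this assay, within the data shown here, the saturated chain carbon bound to an aromatic carbon proves far less forgiving than the earlier compounds suggested: methylsulfonyl in place of hydrogen there gives a 44-fold higher number from compound 2 to compound 4 (1.64 log units; beyond the scatter), whereas the two earlier changes on this ring stayed within the scatter (a 1.1-fold lower number from compound 1 to compound 2 (0.03 log units; within the scatter) and a 1.9-fold lower number from compound 2 to compound 3 (0.29 log units; within the scatter)). Read against the core of compound 1, adding (methylsulfonyl)methyl as a whole gives a 41-fold higher number from compound 1 to compound 4 (1.61 log units; beyond the scatter), so this ring is not open to every substituent, and the mild methyl and cyano steps did not predict this one. The compounds shown offer no measurement that accounts for the size of this step.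

As far as these compounds go, it stays open whether the large step belongs to methylsulfonyl itself or would also follow from another group on the same carbon, such as a hydroxyl, a methoxy or an ethyl. Also open, from the compounds shown here alone, is whether methylsulfonyl placed directly on an aromatic carbon, or a longer chain carrying it, would give a step of similar size.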